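Replacing the aromatic ring in a trifluoromethyl ketone series

This account rests on a few compounds, and the source may have more. Where it says the series, first, only, none or still open, it means among the compounds named here.

Measured compounds:
- Compound 1, `COC(=O)C(=O)[C@@H](NC(=O)[C@@H]1CCCN1C(=O)[C@@H](NC(=O)Cn1ccc(=O)n(CC(=O)O)c1=O)C(C)C)C(C)C`: 94%
- Compound 2, `CC(C)[C@H](NC(=O)Cn1ccc(=O)n(CC(=O)O)c1=O)C(=O)N1CCC[C@H]1C(=O)N[C@H](C(=O)C(F)(F)F)C(C)C`: 79%
- Compound 3, `CC(C)[C@H](NC(=O)[C@@H]1CCCN1C(=O)[C@@H](NC(=O)CN1CCN(CC(=O)O)C(=O)C1=O)C(C)C)C(=O)C(=O)NCc1ccccc1`: 89%

The three compounds were tested in a functional assay on the whole organism for inhibition, with Hamster (Cricetinae) as the target, at a dose of 10 mg/kg by the intravenous route; on this read-out higher numbers stand for a stronger effect at the one dose given and lower numbers for a weaker effect. Compound 2 stands lowest of the three numbers, but its gap to compound 3 lies within the scatter, so no order between these two can be claimed; only the gap to compound 1 is beyond the scatter. For the measured compounds named here, the one step that has been measured, a number 15 percentage points lower from compound 1 to compound 2 (beyond the scatter), concerns the carbonyl end of the chain and not the ring.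

Compound 4, `CC(C)[C@H](NC(=O)CN1CCN(CC(=O)O)C1=O)C(=O)N1CCC[C@H]1C(=O)N[C@H](C(=O)C(F)(F)F)C(C)C`, differs from compound 2 at the other end: a group of 10 heavy atoms (5 carbon, 2 nitrogen, 3 oxygen; one five-membered non-aromatic ring with 2 hetero atoms) in place of a group of 12 heavy atoms (6 carbon, 2 nitrogen, 4 oxygen; one six-membered aromatic ring with 2 hetero atoms), on a saturated chain carbon bound to a carbonyl carbon. Going by the values given here, no measured step bears directly on this change. Compound 1 and compound 3 both carry a six-membered ring at this place, the first aromatic and the second not, and their values in this assay are close to each other, although they also differ elsewhere, so they do not isolate the ring. The account therefore expects only a small step, if any, in this assay, with a slight lean downward, giving compound 2 to compound 4 an expected step of a number 7 percentage points lower from compound 2 to compound 4 (within the scatter). Compound 4 is estimated at 72%, within a range of 50% to 90%.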

Compound 4, a percentage reported as inhibition, in the whole organism at one dose (the size of the read-out at that dose, not a potency): 97%
For compound 4 the middle estimate is 25 percentage points below the measured one, outside the stated range (above it).
By their numbers in this assay, from the lowest: compounds 2, 3, 1 and 4 (each within the scatter of the next, the first and the last beyond it).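

Within the trifluoromethyl ketone series, putting 3-(carboxymethyl)-2-oxoimidazolidin-1-yl on a saturated chain carbon bound to a carbonyl carbon, where the six-membered aromatic ring stood, gives a number 18 percentage points higher from compound 2 to compound 4 (beyond the scatter) in this assay at the one dose tested. For the compounds shown here, this is the first step read at this end of the molecule, and it shows that in this pair the aromatic ring is not needed to keep the read-out high, since the five-membered non-aromatic ring with fewer heavy atoms gives the larger effect. No measurement at hand bears on what lies behind this step.

The single change alters ring size, aromatic character and the number of double bonds outside aromatic rings all at once, so the compounds shown cannot assign the step to any one of these, and a single-dose read-out says nothing of potency. A saturated six-membered ring on the same trifluoromethyl ketone would begin to separate these factors, and a propanoic acid chain or a methyl ester in place of the carboxymethyl group would test whether the carboxylic acid arm matters here.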